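The source may report more compounds than this note shows. Statements on the series, on what has been measured and on what is new or still open speak of the compounds shown alone.

Compound 1 `Cn1nnnc1SCC(=O)N/N=C/c1ccccc1` is a small hydrazone built on a methylated tetrazole core. In an ADME assay on NIH3T3 cells (Mus musculus) for cytotoxicity, read by XTT assay, with a stated time of 24 h (on this read-out lower numbers stand for stronger inhibition and higher numbers for weaker inhibition), compound 1 gives 9700000 nM. Within the data shown here, only one other compound has been measured: compound 2 `Cn1nnnc1SCC(=O)N/N=C/c1ccc([N+](=O)[O-])cc1`, in which a nitro group sits on the benzene ring, and in this assay compound 2 gives 9300000 nM. The two numbers lie within the scatter of each other, so neither can be told apart from the other on this read-out; the step of a 1.0-fold lower number from compound 1 to compound 2 (0.02 log units; within the scatter) says as much.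

Compound 3 `Cn1nnnc1SCC(=O)N/N=C/c1ccccc1[N+](=O)[O-]` has not been measured. Its difference from compound 1 is nitro in place of hydrogen on an aromatic carbon. Among the measured compounds shown here, the only step that bears on it, from compound 1 to compound 2, was within the scatter, and it concerned the same kind of change at another place on the ring. The step of a 1.0-fold lower number from compound 1 to compound 3 (0.01 log units; within the scatter) is therefore expected to be none beyond the scatter. Compound 3 is estimated at 9500000 nM, with a likely range from 4000000 nM to 22000000 nM.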

Compound 3, half-maximal inhibitory concentration: 2020000 nM
Beside the measured number, compound 3's estimate is 4.7-fold (0.67 log units) above it; measured number below the stated range.
By their numbers in this assay, from the lowest: compound 3; then compounds 2 and 1 (each within the scatter of the next).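

With a nitro group ortho to a large group, this assay shows a 4.8-fold lower number from compound 1 to compound 3 (0.68 log units; beyond the scatter), whereas the same group at another place on the ring showed only a 1.0-fold lower number from compound 1 to compound 2 (0.02 log units; within the scatter). The earlier pair suggested that adding nitro to the ring changes little here, but this result shows that the outcome depends on where the group sits. The change is modest, yet it is the first difference among these compounds that stands clear of the usual scatter. No measurement shown here explains why the place of the nitro group matters. As far as these compounds go, it remains open whether an amine, a carboxylic acid or a methyl group at this same place would lower the number too. The compounds shown therefore cannot tell whether the drop is particular to nitro or would follow from other groups there.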